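A few compounds are considered here, and "the series" means these few. Any claim that something is new, unique, unknown or untested is made for them only; others in the source may bear on it.

Working notes on the series, step from compound 2 to compound 3.

Compound 1 `CC(C)N(Cc1cccc(OCCCCCC(=O)O)c1)C(=O)c1ccccc1` carries hydrogen on the aromatic carbon in question. In an ADME assay on HEK293 cells (Homo sapiens) for cytotoxicity, read by CellTiter-Glo and resazurin assay, with a stated time of 72 h (a lower number here means that less compound is needed, a higher number that more compound is needed for the effect), compound 1 returns only a limit of the assay, > 26000 nM. Compound 2 `CC(C)Oc1cccc(-c2ccc(C(=O)N(Cc3cccc(OCCCCCC(=O)O)c3)C(C)C)cc2)c1` carries 3-isopropoxyphenyl in place of hydrogen on an aromatic carbon. In this assay compound 2 also returns only a limit of the assay, > 26000 nM. The step that the two limits leave unreadable from compound 1 to compound 2 is therefore of unreadable size, because both ends sit at the limit of > 26000 nM in this assay, at which 2 of the 2 values shown sit. Among the measured compounds shown here, compound 2 thus stands at a limit, and the one further value shown for comparison is a limit as well, so no readable number places it.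

Compound 3 `COc1cc(F)cc(-c2ccc(C(=O)N(Cc3cccc(OCCCCCC(=O)O)c3)C(C)C)cc2)c1` is not yet measured. The change from compound 2 is 3-fluoro-5-methoxyphenyl in place of 3-isopropoxyphenyl on an aromatic carbon. For the measured compounds named here, the only measured step that bears on it is the one from compound 1 to compound 2, and its size cannot be read because both values sit at the limit of > 26000 nM in this assay, at which 2 of the 2 values shown sit. No readable step exists, so no step beyond the scatter is expected in this assay. For compound 3 the value in this assay is estimated at 30000 nM, within 15000 nM to 60000 nM. The step that the limit leaves unreadable from compound 2 to compound 3 is expected to stay within the scatter, most likely as a further limit.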

Compound 3, half-maximal effective concentration: > 26000 nM
Compound 3 ended at the assay's limit (the forecaster's own chance of this, stated with the estimate: 85%); the middle value is on the limit's open side.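

No step can be read among compound 1, compound 2 and compound 3 in this assay, because each of the three returns only a limit of the assay: the limit of > 26000 nM in this assay, at which 3 of the 3 values shown sit.

The compounds shown leave open whether hydrogen, 3-isopropoxyphenyl and 3-fluoro-5-methoxyphenyl on this aromatic carbon differ at all in this assay.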